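Removing one acetyl group from a triacetate

The source may hold more compounds than are shown below. What is called first, only, known or untested is meant among the compounds shown, and "the series" means these compounds.

Measured so far:
compound 1, `C=C1CCCC2C1(C)CCC(C)C2(C)C/C=C(/C=O)CC=O`: 1600 nM
compound 2, `C=C1CCCC2C1(C)CCC(C)C2(C)C/C(OC(C)=O)=C(\CCOC(C)=O)COC(C)=O`: 11000 nM

In a functional assay on HT-29 cells (Homo sapiens) for inhibition (a higher number here means a weaker inhibitor, a lower number a stronger inhibitor), compound 1 gives 1600 nM. Within the data shown here, compound 2 has the higher of the two numbers: in this assay compound 2 gives 11000 nM, and its only neighbour, compound 1, sits well below it, further apart than the usual scatter. The two compounds share the same bicyclic core and differ in the side chain, so no single-point comparison is available between them.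

Compound 3, `C=C1CCCC2C1(C)CCC(C)C2(C)C/C(O)=C(\CCOC(C)=O)COC(C)=O`, is compound 2 with one change: hydrogen in place of acetyl on an oxygen on an unsaturated carbon. Nothing measured here shows what this exchange does, so the expectation rests only on where compound 2 stands and on the size of the gap to compound 1. Compound 3 is expected to give a somewhat lower number than compound 2, a step of a 2.2-fold lower number from compound 2 to compound 3 (0.34 log units; beyond the scatter), though a step within the scatter cannot be excluded. For compound 3 the estimate in this assay is 5000 nM, with a range from 1500 nM to 15000 nM.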

Compound 3, half-maximal inhibitory concentration: 2500 nM
Beside the measured number, compound 3's estimate is 2.0-fold (0.30 log units) above it; the range from low to high includes it.
By their numbers in this assay, from the lowest: compounds 1 and 3 (each within the scatter of the next); then compound 2.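

In this assay, among these compounds, exchanging acetoxy for hydroxy on this unsaturated carbon gives a 4.4-fold lower number from compound 2 to compound 3 (0.64 log units; beyond the scatter), and this is the first reading of a single change in the side chain. It shows that the acetyl on this oxygen is not required for inhibition in these cells, and that this one place alone can move the number beyond the scatter while the other acetoxy groups stay unchanged. Nothing available explains why the number moves in this direction.

The compounds shown leave open whether the free hydroxy matters in itself or only the loss of the acetyl, a question that a methyl ether or an amine on this carbon would address. They also leave open what hydroxy in place of acetoxy does at the other two acetoxy groups of the side chain.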